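Replacing the isopropyl group of compound 3 with hydrogen

The source may report more compounds than this note shows. Statements on the series, on what has been measured and on what is new or still open speak of the compounds shown alone.

Values in a functional assay on MCF7 cells (Homo sapiens) for inhibition, read by MTT assay, with a stated time of 72 h; a lower number here means a stronger inhibitor, a higher number a weaker inhibitor:
- compound 1 `CC(C)[C@H](NC(=O)c1cc(Cl)ccc1OCCNC(=O)OCc1ccccc1)C(=O)Nc1ccc([N+](=O)[O-])cc1Cl`: > 10000 nM (a limit)
- compound 2 `CC(C)[C@H](NC(=O)c1cc(Cl)ccc1OCCCCNC(=O)OC(C)(C)C)C(=O)Nc1ccc([N+](=O)[O-])cc1Cl`: > 10000 nM (a limit)
- compound 3 `CC(C)[C@H](NC(=O)c1cc(Cl)ccc1OCCN)C(=O)Nc1ccc2c(c1)S(=O)(=O)C=C2`: 4350 nM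

For the measured compounds named here, compound 3, at 4350 nM, holds the only true number. The other two values sit at the limit of > 10000 nM in this assay, at which 2 of the 3 values shown sit.

The change to compound 4 `NCCOc1ccc(Cl)cc1C(=O)NCC(=O)Nc1ccc2c(c1)S(=O)(=O)C=C2` is hydrogen in place of isopropyl on a saturated chain carbon bound to an amide-type nitrogen and a carbonyl carbon.

Going by the values given here, the only measured step, a step that the two limits leave unreadable from compound 1 to compound 2, lies elsewhere in the structure and has no readable size, so it offers no guide here. On the structural change alone, a weakening in this assay is tentatively expected. The expected change is a 2.1-fold higher number from compound 3 to compound 4 (0.32 log units; beyond the scatter). Compound 4 is estimated at 9000 nM, with an expected range of 3000 nM to 30000 nM.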

Compound 4, half-maximal inhibitory concentration: 9440 nM
Compound 4: middle estimate off by 1.0-fold (0.02 log units), on the low side; the measured number falls inside the stated range.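

In this assay, for the compounds shown here, hydrogen in place of isopropyl on the saturated chain carbon gives a 2.2-fold higher number from compound 3 to compound 4 (0.34 log units; beyond the scatter) as the first readable step. The isopropyl group is therefore not required for a measurable value, since compound 4 still gives a true number, but its loss carries a modest cost. The other values remain limits of the assay: the limit of > 10000 nM in this assay, at which 2 of the 4 values shown sit.

As far as these compounds go, whether a methyl, benzyl or cyclohexyl group at this carbon would give a lower number than isopropyl remains open. So does the effect of a longer chain there.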